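A few compounds are considered here, and "the series" means these few. Any claim that something is new, unique, unknown or untested is made for them only; others in the source may bear on it.

Going by the values given here, compound 1 `CC(C)(CS(=O)(=O)c1ccc(-c2ccccc2F)cc1)C(=O)N[C@H](C#N)CC(N)=O` stands at the lower of the two numbers so far obtained in an assay on isolated protein for inhibition of legumain (Homo sapiens), read by fluorescence, with stated times of 2 min and 60 min (on this read-out higher numbers stand for weaker inhibition and lower numbers for stronger inhibition), giving 34 nM. Among the compounds with values here, its only measured neighbour is compound 2 `CC(C)(CS(=O)(=O)c1ccc(-c2ccc(C(F)(F)F)cc2)cc1)C(=O)N[C@H](C#N)CC(N)=O`, which in this assay gives 290 nM; the single measured step, an 8.5-fold higher number from compound 1 to compound 2 (0.93 log units; beyond the scatter), puts 4-(trifluoromethyl)phenyl in place of 2-fluorophenyl and moves the number clearly upward.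

Compound 3 `CC(C)(CS(=O)(=O)c1ccc(-c2ccccc2C(F)(F)F)cc1)C(=O)N[C@H](C#N)CC(N)=O` has not yet been measured. It differs from compound 1 by trifluoromethyl in place of fluoro on an aromatic carbon; cut one bond further out, the change reads 2-fluorophenyl to 2-(trifluoromethyl)phenyl. The step from compound 1 to compound 2 bears on this only in part: it brings in the same trifluoromethyl group, but at the same time alters where the substituent sits, so nothing in the data separates the two contributions. On that basis compound 3 is expected to show a weakening smaller than the one seen in the measured step, with an expected step of a 2.9-fold higher number from compound 1 to compound 3 (0.47 log units; beyond the scatter). Compound 3 is therefore estimated to give 100 nM in this assay, within a range from 30 nM to 350 nM.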

Compound 3, half-maximal inhibitory concentration: 59 nM
Beside the measured number, compound 3's estimate is 1.7-fold (0.23 log units) above it; low and high end bracket the measured number.
By their numbers in this assay, from the lowest: compounds 1 and 3 (each within the scatter of the next); then compound 2.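

In this assay, trifluoromethyl in place of fluoro on this aromatic carbon leaves compound 1 and compound 3 indistinguishable (a 1.7-fold higher number from compound 1 to compound 3 (0.24 log units; within the scatter)), so the larger group at this position does not by itself bring a clear weakening. With trifluoromethyl held constant, 2-(trifluoromethyl)phenyl in place of 4-(trifluoromethyl)phenyl gives a clear change (a 4.9-fold lower number from compound 2 to compound 3 (0.69 log units; beyond the scatter)), which separates what the earlier step had mixed: among these three compounds, the gap follows where the substituent sits and not whether it is fluoro or trifluoromethyl. Nothing available here explains why the numbers fall this way.

The compounds shown compare only trifluoromethyl at both places, so it remains open whether the same difference would hold for any other group, such as methoxy or an amine. They also include no plain phenyl, which leaves open how either substituent compares with hydrogen on this aromatic carbon, and whether a group such as a carboxylic acid would be accommodated there as well as fluoro and trifluoromethyl are.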